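Sulfonyl substituent change on the terminal aryl urea

The source may hold more compounds than are shown below. What is called first, only, known or untested is meant among the compounds shown, and "the series" means these compounds.

Measured compounds in a functional assay on MDA-MB-231 cells (Homo sapiens) for antiproliferative activity, read by MTT assay, with a stated time of 72 h; on this read-out higher numbers stand for weaker inhibition and lower numbers for stronger inhibition:
Compound 1 `Cc1ccc(NC(=O)Nc2cccc(-c3nc(-c4ccc(NC(=O)c5cccnc5)cc4Cl)no3)c2)cc1` gives 3500 nM.
Compound 2 `C#Cc1ccc(NC(=O)Nc2cccc(-c3nc(-c4ccc(NC(=O)c5cccnc5)cc4Cl)no3)c2)cc1` reaches only the assay limit, > 10000 nM.
Compound 3 `NS(=O)(=O)Nc1ccc(NC(=O)Nc2cccc(-c3nc(-c4ccc(NC(=O)c5cccnc5)cc4Cl)no3)c2)cc1` gives 8900 nM.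

Compound 3 holds the higher of the two numbers obtained, its nearest neighbour being compound 1 with a 2.5-fold higher number from compound 1 to compound 3 (0.41 log units; beyond the scatter); the remaining value of the set is a limit (the limit of > 10000 nM in this assay, at which 1 of the 3 values shown sits). Compound 4 `O=C(Nc1ccc(NS(=O)(=O)C2CC2)cc1)Nc1cccc(-c2nc(-c3ccc(NC(=O)c4cccnc4)cc3Cl)no2)c1` differs from compound 3 by cyclopropyl in place of amino on a sulfonyl sulfur. Among the compounds with values here, no measured step alters the sulfonyl sulfur itself; the closest guidance is an at least 1.1-fold lower number from compound 2 to compound 3 (0.05 log units; that floor lies within the scatter), which lies within the scatter, and the modest 2.5-fold higher number from compound 1 to compound 3 (0.41 log units; beyond the scatter), both touching the same terminal ring. For compound 4 a step of a 1.3-fold lower number from compound 3 to compound 4 (0.10 log units; within the scatter) is therefore expected, no larger than the scatter in either direction. Compound 4 is estimated at 7000 nM, within 2500 nM to 20000 nM.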

Compound 4, half-maximal inhibitory concentration: 300 nM
The estimate for compound 4 lay 23-fold (1.37 log units) above the measured number; measured number below the stated range.
By their numbers in this assay, from the lowest: compound 4; then compound 1; then compound 3. At a limit, above all of these: compound 2.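

On the sulfonyl sulfur, cyclopropyl in place of amino gives a 30-fold lower number from compound 3 to compound 4 (1.47 log units; beyond the scatter), so in this assay the read-out responds strongly to the group on that sulfur, which the earlier terminal-ring changes did not show. Compound 4 alone improves on the methyl compound, with a 12-fold lower number from compound 1 to compound 4 (1.07 log units; beyond the scatter), and against ethynyl the change is an at least 33-fold lower number from compound 2 to compound 4 (1.52 log units; beyond the scatter). Compound 2 stands at a limit, so that last step is a floor: the limit of > 10000 nM in this assay, at which 1 of the 4 values shown sits.

From the compounds shown here alone, whether the gain needs the three-membered ring remains open. Methyl, a longer chain or a dimethylamino group on the sulfonyl sulfur would test this.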